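The source may hold more compounds than are shown below. What is called first, only, known or untested is meant among the compounds shown, and "the series" means these compounds.

Measured compounds in an assay on CHO cells for displacement of a labelled ligand from adenosine receptor A3 (Homo sapiens), read by scintillation counting, with a stated time of 45 min, in the presence of a further agent that is not named here; on this read-out higher numbers stand for weaker inhibition and lower numbers for stronger inhibition:
- compound 1 `CCCn1c(=O)[nH]c2nc(-c3ccc(S(=O)(=O)N4CCN(c5cccc(Br)c5)CC4)cc3)[nH]c2c1=O`: > 1000 nM, a limit of the assay
- compound 2 `CCCn1c(=O)[nH]c2nc(-c3ccc(S(=O)(=O)N4CCN(c5ccccc5Cl)CC4)cc3)[nH]c2c1=O`: > 1000 nM, a limit of the assay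
- compound 3 `CCCn1c(=O)[nH]c2nc(-c3ccc(S(=O)(=O)N4CCN(c5ccc(Cl)cc5F)CC4)cc3)[nH]c2c1=O`: > 1000 nM, a limit of the assay

Compound 1 stands at a limit in this assay, not at a number. The same holds for compound 2 and for compound 3, so that all three values sit at one point (the limit of > 1000 nM in this assay, at which 3 of the 3 values shown sit). The steps a step that the two limits leave unreadable from compound 1 to compound 2, a step that the two limits leave unreadable from compound 1 to compound 3 and a step that the two limits leave unreadable from compound 2 to compound 3 therefore carry no readable size, and none of the three aryl groups on the ring nitrogen shows itself as readably different from the others.

Compound 4 `CCCn1c(=O)[nH]c2nc(-c3ccc(S(=O)(=O)N4CCN(c5ccccc5C)CC4)cc3)[nH]c2c1=O` differs from compound 1 as follows: 2-methylphenyl in place of 3-bromophenyl on an amine nitrogen in a ring. The measured steps bear on this change only in that every exchange of the aryl group tried so far left the value at the limit (the limit of > 1000 nM in this assay, at which 3 of the 3 values shown sit). Going by the values given here, no direction of step in this assay can be read from them, and no step beyond the scatter is expected, a step that the limit leaves unreadable from compound 1 to compound 4 being the estimated step. Compound 4 is accordingly expected at 3000 nM, with a range of 1000 nM to 20000 nM, most likely again reported as a limit.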

Compound 4, inhibition constant: > 1000 nM
Compound 4: only a limit was reported; the forecaster's own chance of this, stated with the estimate: 85%; the middle value is on the limit's open side.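

In this assay compound 4 gives > 1000 nM, a limit of the assay. The steps linking compound 4 with compound 1, compound 2 and compound 3 cannot be read: the limit of > 1000 nM in this assay, at which 4 of the 4 values shown sit. The compounds shown leave open whether any of these aryl groups differs from the others in this read-out.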